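This account rests on a few compounds, and the source may have more. Where it says the series, first, only, none or still open, it means among the compounds named here.

The measured compounds and their numbers:

Compound 1, `COc1ccccc1NC(=O)Nc1cccc(CNc2ncnc3ccccc23)c1`: 17500 nM
Compound 2, `COc1ccc(NC(=O)Nc2cccc(CNc3ncnc4ccccc34)c2)cc1`: its number is a limit of the assay, > 50000 nM
Compound 3, `COc1cc2ncnc(NCc3cccc(NC(=O)Nc4cccc(C)c4)c3)c2cc1OC`: 21500 nM

In a functional assay on HepG2 cells (Homo sapiens) for antiproliferative activity, read by MTT assay (a higher number here means a weaker inhibitor, a lower number a stronger inhibitor), compound 1 gives 17500 nM. The value of compound 2 is a limit of the assay and not a number. Within the data shown here, the one step between compounds that differ in a single place is an at least 2.8-fold higher number from compound 1 to compound 2 (0.45 log units; beyond the scatter), so moving the methoxy group on that ring mattered there, at least modestly. Compound 3 has the highest of the two plain numbers, but its value sits within the scatter of that of compound 1, so the two cannot be ordered.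

Compound 4, `COc1cc2ncnc(NCc3cccc(NC(=O)Nc4ccccc4Cl)c3)c2cc1OC`, is reached from compound 3 by one exchange: 2-chlorophenyl in place of 3-methylphenyl on an amide-type nitrogen. Among the measured compounds shown here, the only measured step concerns a methoxy group shifting position on the same phenyl ring, a different exchange from this one, so it gives no direct guide to direction. The expectation is therefore for at most a modest step, a 1.1-fold lower number from compound 3 to compound 4 (0.03 log units; within the scatter), as the estimate for compound 4 in this assay is 20000 nM, within a range from 8000 nM to 50000 nM.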

Compound 4, half-maximal inhibitory concentration: 25500 nM
Estimate against measurement, compound 4: 1.3-fold (0.11 log units) below; low and high end bracket the measured number.
By their numbers in this assay, from the lowest: compounds 1, 3 and 4 (each within the scatter of the next). At a limit, above all of these: compound 2.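

In this assay, the exchange on the amide-type nitrogen gives a 1.2-fold higher number from compound 3 to compound 4 (0.07 log units; within the scatter), so on the core shared by these two compounds, 2-chlorophenyl and 3-methylphenyl cannot be told apart. The two groups match in every count computed for them, including heavy atoms and hydrogen-bond donors and acceptors, but they differ both in the atom they carry and in where it sits on the ring, and this single step cannot separate those two differences. Nothing measured here points to a cause for this result.

Going by these compounds, it remains open whether a methyl group and a chlorine atom placed alike on that ring would give different numbers, and whether a ring carrying an amine or a carboxylic acid would move the number beyond the scatter. Also open, on these data alone, is whether shifting a methoxy group, which mattered between compound 1 and compound 2, would matter in the same way on the core of compound 3 and compound 4, with 2-methoxyphenyl and 4-methoxyphenyl on this nitrogen.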